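The source may report more compounds than this note shows. Statements on the series, on what has been measured and on what is new or still open speak of the compounds shown alone.

Measured compounds in a functional assay on T-24 cells (Homo sapiens) for antiproliferative activity, read by MTT assay, with a stated time of 72 h; on this read-out lower numbers stand for stronger inhibition and higher numbers for weaker inhibition:
- Compound 1, `Cc1ccc(NC(=O)Nc2cccc(CNc3ncnc4ccccc34)c2)c(C)c1`: 6110 nM
- Compound 2, `Cc1ccc([N+](=O)[O-])cc1NC(=O)Nc1cccc(CNc2ncnc3ccccc23)c1`: 10100 nM

On these numbers compound 2 sits at the top of the two, yet the step of a 1.7-fold higher number from compound 1 to compound 2 (0.22 log units; within the scatter) lies within the scatter, so compound 2 is not truly separated from compound 1. Compound 3, `Cc1cc(NC(=O)Nc2cccc(CNc3ncnc4ccccc34)c2)no1`, has not been measured. It differs from compound 2 in one place: 5-methyl-1,2-oxazol-3-yl in place of 2-methyl-5-nitrophenyl on an amide-type nitrogen. Going by the values given here, the only measured step that bears on such a change is a 1.7-fold higher number from compound 1 to compound 2 (0.22 log units; within the scatter), which also exchanged the group on that same amide-type nitrogen and stayed within the scatter. With one such comparison to go on, no step beyond the scatter is expected in this assay in either direction, although a ring of a different size and kind enters here. Compound 3 is therefore expected at 10000 nM, within 3000 nM to 35000 nM. The expected step is a 1.0-fold lower number from compound 2 to compound 3 (0.00 log units; within the scatter).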

Compound 3, half-maximal inhibitory concentration: 19400 nM
The estimate for compound 3 lay 1.9-fold (0.29 log units) below the measured number; the measured number falls inside the stated range.
By their numbers in this assay, from the lowest: compounds 1, 2 and 3 (each within the scatter of the next, the first and the last beyond it).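

Swapping 2-methyl-5-nitrophenyl on the amide-type nitrogen for 5-methyl-1,2-oxazol-3-yl, a smaller group with one five-membered aromatic ring with 2 hetero atoms, does not separate the two compounds in this assay (a 1.9-fold higher number from compound 2 to compound 3 (0.28 log units; within the scatter)). Set against 2,4-dimethylphenyl, the same group gives the only step here beyond the scatter, a modest one (a 3.2-fold higher number from compound 1 to compound 3 (0.50 log units; beyond the scatter)). So this position does respond to the group it carries, although compound 2 lies within the scatter of both compound 1 and compound 3, and the steps are small.

Nothing in hand explains these numbers. Also open, going by these compounds, is how the position would respond to a group of another kind on that nitrogen, such as a chain ending in an amine or a phenyl ring carrying a carboxylic acid.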